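The source may report more compounds than this note shows. Statements on the series, on what has been measured and on what is new or still open speak of the compounds shown alone.

Compound 2, `Oc1cccc(-c2cc(-c3ccncc3)nc(-c3cccc(Cl)c3)c2)c1`, was examined in an assay on isolated protein for inhibition of DNA topoisomerase 1 (Homo sapiens), with a stated time of 30 min, tested at 100 uM (a lower number here means a weaker effect, a higher number a stronger effect of the compound at the concentration tested), and gave 0%. Compound 3, `Oc1cccc(-c2cc(-c3cccnc3)nc(-c3ccccc3Cl)c2)c1`, gave 0% in this assay, so the two stand level at the digits shown and together at the bottom of the three measured numbers. Compound 1, `Oc1ccc(-c2cc(-c3ccccc3)nc(-c3ccccc3Cl)c2)cc1`, gave 13.6% in this assay, a number that lies above the pair by more than the usual scatter of such measurements, while the gap between compound 2 and compound 3 lies within it.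

The unmeasured compound 4, `Oc1cccc(-c2cc(-c3cccc(Cl)c3)nc(-c3ccco3)c2)c1`, is reached from compound 2 by one change: furan-2-yl in place of pyridin-4-yl on an aromatic carbon. Among the measured compounds shown here, no measured pair in this set shows this particular exchange, so no measured step can be read for it.

Because compound 2 gives 0% and compound 3 gives 0%, little movement is expected, and the step of a number 5 percentage points higher from compound 2 to compound 4 (within the scatter) is estimated to stay within the scatter. Compound 4 is expected to give about 5% in this assay, with a range from 0% to 20%.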

Compound 4, a percentage reported as inhibition, at one concentration (the size of the read-out at that concentration, not a potency): 5.5%
Estimate against measurement, compound 4: 0.5 percentage points below; the range from low to high includes it.
By their numbers in this assay, from the lowest: compounds 2, 3, 4 and 1 (each within the scatter of the next, the first and the last beyond it).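

In this assay, among the compounds shown here, furan-2-yl in place of pyridin-4-yl on the aromatic carbon next to the ring nitrogen gives a number 5.5 percentage points higher from compound 2 to compound 4 (within the scatter) and is the first step in this set that can be read at this position. It shows that a five-membered aromatic ring with an oxygen can take the place of a six-membered aromatic ring with a nitrogen here while the read-out stays within the scatter of compound 2. Nothing shown gives a reason for this result.

The compounds shown leave open whether any group at this position would move the read-out beyond the scatter, for example thiophen-2-yl, an amine or a carboxylic acid. They also leave open what the 3-chlorophenyl and 3-hydroxyphenyl groups contribute, as no single change at either place can be read.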